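Chain terminus variation at the shared core

The source may hold more compounds than are shown below. What is called first, only, known or untested is meant among the compounds shown, and "the series" means these compounds.

Compound 3 `CCCCCc1c(C)nc(N)nc1NCCCC` gives 1220 nM in an assay on HEK293 cells for agonist activity at Toll-like receptor 8 (Homo sapiens), read by spectrophotometry (on this read-out higher numbers stand for an effect only at larger amounts of compound and lower numbers for an effect already at smaller amounts), level with compound 1 `CCCCNc1nc(N)nc(C)c1CCCC(C)(C)O` at 1220 nM; together these are the highest numbers of the three measured, and the step of no change at the digits printed from compound 1 to compound 3 (within the scatter) lies within the scatter. Compound 2 `CCCCNc1nc(N)nc(C)c1CCCN1CCCCCC1` gives 178 nM, the step of a 6.9-fold higher number from compound 2 to compound 3 (0.84 log units; beyond the scatter) being beyond the scatter. Compound 4 `CCCCNc1nc(N)nc(C)c1CCCc1ccccc1` carries the change (phenyl in place of ethyl on a saturated chain carbon, three bonds along the chain from an aromatic carbon). Of the measured steps only a 6.9-fold higher number from compound 2 to compound 3 (0.84 log units; beyond the scatter) involves a ring entering at this place, and it is modest; no change at the digits printed from compound 1 to compound 3 (within the scatter) shows a swap of small groups with no effect. Since the entering phenyl brings no donor and no acceptor, a step smaller than that of compound 2 is expected. For compound 4 a modest lowering a 2.0-fold lower number from compound 3 to compound 4 (0.31 log units; beyond the scatter) is estimated, giving 600 nM with a range of 200 nM to 1500 nM.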

Compound 4, half-maximal effective concentration: 749 nM
For compound 4 the middle estimate is 1.2-fold (0.10 log units) below the measured one; low and high end bracket the measured number.
By their numbers in this assay, from the lowest: compound 2; then compounds 4, 1 and 3 (each within the scatter of the next).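

A ring entering at this place does not by itself give the lower number: with phenyl, the steps (a 1.6-fold lower number from compound 3 to compound 4 (0.21 log units; within the scatter)) and (a 1.6-fold lower number from compound 1 to compound 4 (0.21 log units; within the scatter)) both stay within the scatter. Only the azepan-1-yl of compound 2 stands apart from the other termini, and the step to phenyl (a 4.2-fold higher number from compound 2 to compound 4 (0.62 log units; beyond the scatter)) lies beyond the scatter.

As far as these compounds go, whether that gap follows the ring nitrogen or the ring itself stays open; a piperidin-1-yl, a diethylamino group or a pyridyl at this place would separate the two. No measurement at hand explains these steps.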